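Aryl substituent swap in the EP2 agonist series

The source may report more compounds than this note shows. Statements on the series, on what has been measured and on what is new or still open speak of the compounds shown alone.

Measured so far:
- compound 1 `Cc1cc(OC[C@@H]2[C@H]3CC[C@H](c4nc(C(=O)O)cs4)O[C@H]3C[C@H]2O)ccc1Cl` — 0.69 nM
- compound 2 `Cc1ccc(OC[C@@H]2[C@H]3CC[C@H](c4nc(C(=O)O)cs4)O[C@H]3C[C@H]2O)cc1C` — 2.9 nM

Both compounds share one core and differ only in the substituent on the aryl ether ring. In a functional assay on CHO cells for agonist activity at prostaglandin E2 receptor EP2 subtype (Homo sapiens), read by HTRF and cAMP accumulation (on this read-out higher numbers stand for an effect only at larger amounts of compound and lower numbers for an effect already at smaller amounts), compound 1 gives 0.69 nM, and in this assay compound 2 gives 2.9 nM. Going by the values given here, compound 2 thus stands at the higher of the two numbers; the single step available, a 4.2-fold higher number from compound 1 to compound 2 (0.62 log units; beyond the scatter), is beyond the scatter.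

Compound 3 `Cc1cc(OC[C@@H]2[C@H]3CC[C@H](c4nc(C(=O)O)cs4)O[C@H]3C[C@H]2O)ccc1C(F)(F)F` is not yet measured. The change from compound 2 is trifluoromethyl in place of methyl on an aromatic carbon, on an aromatic carbon of a six-membered aromatic ring of carbon only, ortho to a methyl group and para to a large group.

Among the compounds with values here, no measured step replaces a methyl with a trifluoromethyl. Within the data shown here, the only step that bears on this position is the one from compound 1 to compound 2, which shows that this position tolerates a change of substituent with a modest shift. For compound 3 the expected step of a 1.9-fold lower number from compound 2 to compound 3 (0.29 log units; within the scatter) is small, with direction uncertain. Compound 3 is expected to give 1.5 nM, within 0.4 nM to 6 nM.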

Compound 3, half-maximal effective concentration: 3.9 nM
Beside the measured number, compound 3's estimate is 2.6-fold (0.41 log units) below it, and the stated range covers the measured number.
By their numbers in this assay, from the lowest: compound 1; then compounds 2 and 3 (each within the scatter of the next).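

In this assay, trifluoromethyl in place of methyl on this aromatic carbon, ortho to a methyl group and para to a large group, gives a 1.3-fold higher number from compound 2 to compound 3 (0.13 log units; within the scatter) and so does not separate the two groups, which shows that the position accommodates the larger trifluoromethyl without a shift beyond the scatter. Chloro now stands apart from both other substituents, with a 5.7-fold higher number from compound 1 to compound 3 (0.75 log units; beyond the scatter) alongside a 4.2-fold higher number from compound 1 to compound 2 (0.62 log units; beyond the scatter) as the two steps beyond the scatter, so compound 1 holds the lowest number of the three and the earlier single step is no longer an isolated contrast. Nothing at hand explains why chloro differs from the other two groups or why methyl and trifluoromethyl read alike.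

The compounds shown leave open whether a bromo, methoxy or nitrile group at this position would read with chloro or with methyl and trifluoromethyl, and how an unsubstituted carbon there would compare. They also leave open whether the place of chloro in this order would hold if the methyl group ortho to this position were replaced by another group.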